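The source may hold more compounds than are shown below. What is called first, only, known or untested is meant among the compounds shown, and "the series" means these compounds.

Compound 1, `CN1CCN(c2ccc(C3=NNC(c4ccc(N(C)C)cc4)C3)cc2)CC1`, gives 11.4% in a functional assay on MDA-MB-231 cells (Homo sapiens) for inhibition, read by sulforhodamine B assay, tested at 10 uM; a lower number here means less inhibition, a higher number more inhibition at the concentration tested (going by the name of the read-out).
Compound 2, `CC(=O)N1N=C(c2ccc(N3CCN(C)CC3)cc2)CC1c1ccc(N(C)C)cc1`, gives -1% in this assay.
Compound 3, `Cc1ccc(C(=O)N2N=C(c3ccc(N4CCN(C)CC4)cc3)CC2c2ccc(N(C)C)cc2)cc1`, gives -0.7% in this assay.

Compound 2 sits at the bottom of these three numbers, but its gap to compound 3 is within the usual scatter, so the two cannot be told apart; only compound 1 stands clearly higher than both.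

Compound 4, `CN1CCN(c2ccc(C3=NN(S(=O)(=O)c4ccc(F)cc4)C(c4ccc(N(C)C)cc4)C3)cc2)CC1`, has not yet been measured. It differs from compound 2 at the same amine nitrogen in a ring where compound 2 carries acetyl and compound 1 carries hydrogen: (4-fluorophenyl)sulfonyl in place of acetyl on an amine nitrogen in a ring.

Among the compounds with values here, two measured steps touch this position. Putting acetyl in place of hydrogen gave a number 12.4 percentage points lower from compound 1 to compound 2 (beyond the scatter), and putting (4-methylphenyl)carbonyl in place of hydrogen gave a number 12.1 percentage points lower from compound 1 to compound 3 (beyond the scatter). Exchanging one of these groups for the other gave a number 0.3 percentage points higher from compound 2 to compound 3 (within the scatter). So whatever group sits on that nitrogen in the two measured examples, the inhibition is near zero, and the choice between a small and a larger group made no difference beyond the scatter.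

On this basis compound 4 is expected to stay near zero as well, with the step from compound 2 estimated as a number 3 percentage points higher from compound 2 to compound 4 (within the scatter), that is, none beyond the scatter. The estimate for compound 4 is 2%, within a range from -10% to 15%.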

Compound 4, a percentage reported as inhibition, at one concentration (the size of the read-out at that concentration, not a potency): 15.7%
The estimate for compound 4 lay 13.7 percentage points below the measured number; measured number outside the range, above it.
By their numbers in this assay, from the lowest: compounds 2 and 3 (each within the scatter of the next); then compounds 1 and 4 (each within the scatter of the next).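

In this assay, the group on this amine nitrogen turns out to matter: (4-fluorophenyl)sulfonyl in place of acetyl gives a number 16.7 percentage points higher from compound 2 to compound 4 (beyond the scatter), and in place of (4-methylphenyl)carbonyl it gives a number 16.4 percentage points higher from compound 3 to compound 4 (beyond the scatter). Putting a group on this nitrogen therefore does not always lower the number, since (4-fluorophenyl)sulfonyl in place of hydrogen gives a number 4.3 percentage points higher from compound 1 to compound 4 (within the scatter), so compound 4 cannot be told apart from compound 1, and only the acetyl and (4-methylphenyl)carbonyl groups of compound 2 and compound 3 go with the lower numbers. Nothing available here explains why the sulfonyl-linked group behaves differently from the two carbonyl-linked groups.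

From the compounds shown here alone, the step from compound 3 to compound 4 changes the link to the ring and the group on the ring together, so it remains open whether the sulfonyl link or the fluorine goes with the higher number; (4-methylphenyl)sulfonyl and (4-fluorophenyl)carbonyl on the same nitrogen would separate the two. A simple methylsulfonyl group would likewise show whether the phenyl ring is needed at all.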